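The compounds below may be only part of what the source reports. "The series", "measured", "known", "first", "only" and "open" are said of these compounds alone.

In a functional assay on HepG2 cells (Homo sapiens) for antiproliferative activity, read by MTT assay, with a stated time of 72 h (a higher number here means a weaker inhibitor, a lower number a stronger inhibitor), compound 1 (`COc1cccc(N2C(=O)COc3ccc(-c4ccc(O)cc4)cc32)c1`) gives 26100 nM and compound 2 (`O=C1COc2ccc(-c3cccc(NS(=O)(=O)c4ccc(F)cc4)c3)cc2N1c1ccc(Cl)cc1`) gives 27800 nM while compound 3 (`O=C1COc2ccc(-c3cnc4ccccc4c3)cc2N1`) gives 26300 nM in the same read-out. Compound 2 therefore stands within the scatter of both compound 1 and compound 3, and these three values show no order among them. Compound 4 (`Cc1ccc(N2C(=O)COc3ccc(-c4cccc(NS(=O)(=O)c5ccc(F)cc5)c4)cc32)cc1`) differs from compound 2 at one place (methyl in place of chloro on an aromatic carbon), with methyl in place of chloro on an aromatic carbon, para to a large group, so that 4-chlorophenyl becomes 4-methylphenyl. Within the data shown here, no measured pair shows the effect of this exchange or of any other single change. With compound 2 at 27800 nM as the closest reference, no step beyond the scatter is expected in this assay in either direction. The expected change is a 1.1-fold lower number from compound 2 to compound 4 (0.05 log units; within the scatter) and stays within the scatter. For compound 4 the estimated value is 25000 nM with an expected range from 13000 nM to 48000 nM across repeated measurements.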

Compound 4, half-maximal inhibitory concentration: > 40000 nM
Compound 4: no number, only a limit; the forecaster's own chance of this, stated with the estimate: 10%; middle value at least 1.6-fold (0.20 log units) away from the limit.
By their numbers in this assay, from the lowest: compounds 1, 3 and 2 (each within the scatter of the next). At a limit, above all of these: compound 4.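

Among these compounds, this is the first pair in the set that isolates a single change, and it concerns the group para to a large group on the aromatic ring, where 4-chlorophenyl becomes 4-methylphenyl. Compound 4 has no number, only a limit of the assay: the limit of > 40000 nM in this assay, at which 1 of the 4 values shown sits. In this assay, as far as these compounds go, methyl in place of chloro therefore gives an at least 1.4-fold higher number from compound 2 to compound 4 (0.15 log units; that floor lies within the scatter), so the pair shows no gain from the exchange, while its true size remains unknown and its floor does not establish a real loss.

The compounds shown leave open how an amine or a carboxylic acid would read at this same position in place of chloro or methyl. They also leave open whether the exchange would give the same result on a compound other than compound 2.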